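Swapping fluoro for tert-butyl in compound 2

A few compounds are considered here, and "the series" means these few. Any claim that something is new, unique, unknown or untested is made for them only; others in the source may bear on it.

Of the compounds shown here, three have been measured in a functional assay on A549 cells (Homo sapiens) for antiproliferative activity, read by CCK-8 assay, with a stated time of 72 h; on this read-out lower numbers stand for stronger inhibition and higher numbers for weaker inhibition. Compound 1 (`CCc1ccc(SCc2ccc(C(=O)Nc3ccccc3N)cc2)cc1`) gives 3040 nM, compound 2 (`Nc1ccccc1NC(=O)/C=C/c1ccc(CSc2ccc(F)cc2)cc1`) gives 1190 nM and compound 3 (`Nc1ccccc1NC(=O)c1ccc(CSc2nccc(C(F)(F)F)n2)cc1`) gives 970 nM. Compound 2 therefore lies within the scatter of compound 3, so the two stand level, while compound 1 reads higher than compound 2 by more than the scatter.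

The next compound, not yet measured, is compound 4 (`CC(C)(C)c1ccc(SCc2ccc(/C=C/C(=O)Nc3ccccc3N)cc2)cc1`). It keeps the structure of compound 2 apart from one substituent: tert-butyl in place of fluoro on an aromatic carbon, para to a large group (tert-butyl in place of fluoro on an aromatic carbon). Among the compounds with values here, no two measured compounds differ in one place only, so this change has no direct precedent in the data. The closest hint is compound 1 at 3040 nM, which carries an ethyl group rather than fluoro, but it also differs from compound 2 elsewhere in its structure, so it offers only loose support. A modest weakening is expected in this assay, near the edge of the scatter, and no real change remains possible. The expected size of the change is a 1.7-fold higher number from compound 2 to compound 4 (0.23 log units; within the scatter). For compound 4 the estimated value is 2000 nM, with an expected range from 800 nM to 5000 nM.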

Compound 4, half-maximal inhibitory concentration: 640 nM
Beside the measured number, compound 4's estimate is 3.1-fold (0.49 log units) above it; measured number below the stated range.
By their numbers in this assay, from the lowest: compounds 4, 3 and 2 (each within the scatter of the next); then compound 1.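

In this assay, within the data shown here, putting tert-butyl in place of fluoro gives a 1.9-fold lower number from compound 2 to compound 4 (0.27 log units; within the scatter), the first step in this set that differs in one place only. On this aromatic carbon, para to a large group, four heavy atoms of tert-butyl can therefore stand where the single fluorine stood without a shift beyond the scatter, and the two compounds stand level. The step gives no direction for this change, showing only that this read-out does not separate the two groups here.

No measurement at hand bears on why the two groups read alike.

As far as these compounds go, whether the same position would hold its level with an amine, a carboxylic acid or a longer chain remains open, since the two groups compared here are both free of hydrogen-bond donors and carry no net charge. It is also open whether the change from fluoro to tert-butyl would read the same way on the core of compound 1 or on that of compound 3, as the compounds shown test it on the core of compound 2 alone.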